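Oxazole for Pyrazole on Two Urea Cores

The compounds below may be only part of what the source reports. "The series", "measured", "known", "first", "only" and "open" are said of these compounds alone.

Compound 1 `O=C(NCc1cn[nH]c1)Nc1ccc(S(=O)(=O)c2ccccc2)cc1` and compound 2 `O=C(NCc1cnco1)Nc1ccc(S(=O)(=O)c2ccccc2)cc1` share one core, while compound 3 `CCOC(=O)c1ccc(NC(=O)NCc2cn[nH]c2)cc1` and compound 4 `CCOC(=O)c1ccc(NC(=O)NCc2cnco2)cc1` share another. In an assay on isolated protein for activation of Nicotinamide phosphoribosyltransferase (Homo sapiens) (on this read-out higher numbers stand for an effect only at larger amounts of compound and lower numbers for an effect already at smaller amounts), compound 1 gives 28 nM, and compound 2 gives 77 nM. The step of a 2.8-fold higher number from compound 1 to compound 2 (0.44 log units; beyond the scatter) corresponds to the change (1,3-oxazol-5-yl in place of 1H-pyrazol-4-yl on a saturated chain carbon bound to an amide-type nitrogen). In this assay compound 3 gives 1850 nM, the highest of the three numbers. How the core of compound 3 differs from the core of compound 1 is not broken down here. Compound 4 carries the same kind of change on the second core, (1,3-oxazol-5-yl in place of 1H-pyrazol-4-yl on a saturated chain carbon bound to an amide-type nitrogen), at the same place. Among the measured compounds shown here, only one earlier example of this change exists, so for compound 4 the expected step is a 2.8-fold higher number from compound 3 to compound 4 (0.45 log units; beyond the scatter), which rests on compound 1 and compound 2 because of a 2.8-fold higher number from compound 1 to compound 2 (0.44 log units; beyond the scatter). Compound 4 is therefore estimated at 5200 nM, between 2300 nM and 12000 nM.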

Compound 4, half-maximal effective concentration: 6900 nM
For compound 4 the middle estimate is 1.3-fold (0.12 log units) below the measured one; measured number inside the range.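

On the second core, the change from (1H-pyrazol-4-yl)methyl to (1,3-oxazol-5-yl)methyl again raises the number in this assay, with a 3.7-fold higher number from compound 3 to compound 4 (0.57 log units; beyond the scatter). Set beside the earlier step, the two agree in size: the same change on two cores in this assay, a 2.8-fold higher number (0.44 log units; beyond the scatter) from compound 1 to compound 2 and a 3.7-fold higher number (0.57 log units; beyond the scatter) from compound 3 to compound 4, 1.4-fold (0.13 log units) apart, within the scatter of two such steps. This shows that the change carries over between these two cores with much the same size despite their large difference in value, but two pairs cannot show that it would do so on other cores, nor why the number rises.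

The compounds shown leave open whether the step would hold on a core bearing a carboxylic acid or a primary amide. They also leave open how a 1,3-thiazol-5-yl group or a longer chain would compare at the same place.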